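This account rests on a few compounds, and the source may have more. Where it says the series, first, only, none or still open, it means among the compounds named here.

Working notes on the hydroxycarbamoyl-ended chain series. In a functional assay on HepG2 cells (Homo sapiens) for inhibition, read by MTT assay, with a stated time of 72 h (a lower number here means a stronger inhibitor, a higher number a weaker inhibitor), compound 3 `Nc1nc2cc(-c3nn(CCCC(=O)NO)c4ncnc(N)c34)ccc2o1` is known only as a limit, > 50000 nM. Compound 1 `Nc1ncnc2c1c(-c1cnc3[nH]ccc3c1)nn2CC(=O)NO` is also known only as a limit, > 150000 nM. Among the measured compounds shown here, the one true number so far belongs to compound 2 `Nc1ncnc2c1c(-c1cnc3[nH]ccc3c1)nn2CCCCCCCCC(=O)NO`, which gives 3050 nM. Neither limit gives a firm starting point, so any step from compound 3 can only be judged roughly.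

The next compound is compound 4 `Nc1nc2cc(-c3nn(CCCCCCCCCC(=O)NO)c4ncnc(N)c34)ccc2o1`, which keeps the core of compound 3 and changes only the chain: 6-(hydroxycarbamoyl)hexyl in place of hydroxycarbamoyl on a saturated chain carbon, three bonds along the chain from an aromatic nitrogen. In words, 6-(hydroxycarbamoyl)hexyl stands in place of hydroxycarbamoyl on a saturated chain carbon, three bonds along the chain from an aromatic nitrogen.

For the measured compounds named here, no measured step isolates this change, and the core of compound 2 differs from that of compound 4. The expectation therefore rests on a single comparison: compound 2, which also carries a long saturated chain ending in hydroxycarbamoyl, reads 3050 nM. A step beyond the scatter towards stronger inhibition in this assay is expected, with an estimated size of an at least 20-fold lower number from compound 3 to compound 4 (1.30 log units; beyond the scatter). For compound 4 the estimated value is 2500 nM, with an expected range of 500 nM to 12000 nM.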

Compound 4, half-maximal inhibitory concentration: 28600 nM
For compound 4 the middle estimate is 11-fold (1.06 log units) below the measured one; measured number outside the range, above it.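

In this assay, 6-(hydroxycarbamoyl)hexyl in place of hydroxycarbamoyl on a saturated chain carbon, three bonds along the chain from an aromatic nitrogen, gives an at least 1.7-fold lower number from compound 3 to compound 4 (0.24 log units; that floor lies within the scatter). On these data alone, that floor is all that can be read of the change, and its true size stays unknown because compound 3 is held only as a limit: the limit of > 50000 nM in this assay, at which 1 of the 4 values shown sits.

Among the compounds shown here, compound 4 gives 28600 nM, which puts a true number on this core for the first time and gives later changes to the chain a firm reference that compound 3 could not supply.

As far as these compounds go, what stays open is whether the longer chain truly lowers the number on this core beyond the scatter, since a floor within the scatter neither shows such a step nor rules it out. From the compounds shown here alone, it is also open how a chain of intermediate length or a longer chain would read in this assay on this core, and whether a carboxylic acid in place of the hydroxycarbamoyl end, on the same chain as compound 4, would keep the reading of compound 4.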